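This account rests on a few compounds, and the source may have more. Where it says the series, first, only, none or still open, it means among the compounds named here.

Of the compounds shown here, three built on a shared core have been measured in an assay on isolated protein for inhibition of RAC-alpha serine/threonine-protein kinase (Homo sapiens), read by fluorescence, with a stated time of 30 min, tested at 10 uM; a higher number here means more inhibition at the concentration tested (going by the name of the read-out), a lower number less inhibition. Compound 1 `O=C(Nc1cc(Sc2ncn[nH]2)c(O)c2ccccc12)c1ccc([N+](=O)[O-])cc1` gives 37.3%, compound 2 `O=C(Nc1cc(Sc2ncn[nH]2)c(O)c2ccccc12)c1cccc(Cl)c1` gives 46%, and compound 3 `O=C(Nc1cc(Sc2ncn[nH]2)c(O)c2ccccc12)c1ccc(Cl)cc1` gives 50.1%. Among these three numbers compound 1 stands lowest: the nearest is compound 2, with a number 8.7 percentage points higher from compound 1 to compound 2 (within the scatter), a change within the scatter, and the furthest is compound 3, with a number 12.8 percentage points higher from compound 1 to compound 3 (beyond the scatter), a modest change beyond the scatter. Between the two chlorophenyl compounds the step of a number 4.1 percentage points higher from compound 2 to compound 3 (within the scatter) lies within the scatter.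

Compound 4 `Cc1cccc(C(=O)Nc2cc(Sc3ncn[nH]3)c(O)c3ccccc23)c1` has not yet been measured in this assay. It differs from compound 1 in one place: 3-methylphenyl in place of 4-nitrophenyl on a carbonyl carbon. For the measured compounds named here, the steps that bear on this change are those leading from compound 1 to the two chlorophenyl compounds, a number 8.7 percentage points higher from compound 1 to compound 2 (within the scatter) and a number 12.8 percentage points higher from compound 1 to compound 3 (beyond the scatter); both run upward, one within and one just beyond the scatter. Replacing 4-nitrophenyl with either chlorophenyl has so far given a small rise, and a step of similar size, upward, is expected here, a number 7.7 percentage points higher from compound 1 to compound 4 (within the scatter), although 3-methylphenyl has no measured counterpart among these compounds. Compound 4 is accordingly estimated at 45%, within a range from 32% to 58%.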

Compound 4, a percentage reported as inhibition, at one concentration (the size of the read-out at that concentration, not a potency): 20.2%
Compound 4: the middle estimate sits 24.8 percentage points above what was measured; the whole stated range lies above it.
By their numbers in this assay, from the lowest: compound 4; then compounds 1, 2 and 3 (each within the scatter of the next, the first and the last beyond it).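

Compound 4 shows that a step away from 4-nitrophenyl on this carbonyl carbon can also run downward, a number 17.1 percentage points lower from compound 1 to compound 4 (beyond the scatter), whereas neither chlorophenyl compound had fallen below compound 1, so the outcome of the change depends on the group that enters and not only on the group that leaves. The contrast with the chlorophenyl compounds is wider still: methyl in place of chloro on an aromatic carbon gives a number 25.8 percentage points lower from compound 2 to compound 4 (beyond the scatter), and 3-methylphenyl in place of 4-chlorophenyl gives a number 29.9 percentage points lower from compound 3 to compound 4 (beyond the scatter), so in this assay chloro and methyl on this ring cannot be treated as interchangeable. Nothing at hand bears on what lies behind these falls.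

The compounds shown leave open whether the low reading belongs to the methyl group as such, a question that a phenyl group with no substituent or an ethyl group in its place could help to settle. They also leave open how an amine, a methoxy group or a carboxylic acid on this ring would read, and how far any of these readings at one concentration would carry over to potency.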